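The source may report more compounds than this note shows. Statements on the series, on what has been measured and on what is new or still open speak of the compounds shown alone.

Working notes on the series. Compound 1 `CO[C@@H](C(=O)N[C@@H]1CC[C@H](O)CNC1=O)[C@H](O)[C@@H](O)[C@H](O)/C=C/C(C)(C)C` and compound 2 `CO[C@@H](C(=O)N[C@H]1CC[C@@H](O)CNC1=O)[C@H](O)[C@@H](O)[C@H](O)/C=C/C(C)(C)C` have the same atoms and bonds and differ only in configuration as drawn. In a functional assay on Lu1 cells (Homo sapiens) for cytotoxicity, read by colorimetric assay and neutral red uptake, with a stated time of 72 h (a higher number here means a weaker inhibitor, a lower number a stronger inhibitor), compound 1 gives 36300 nM. In this assay, among the measured compounds shown here, compound 2 gives 23400 nM, the lowest of the two numbers so far, with compound 1 nearest; the step of a 1.6-fold lower number from compound 1 to compound 2 (0.19 log units; within the scatter) lies within the scatter, which rests on (the fact that compounds 1 and 2 differ only in the configuration as drawn).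

Compound 3 `CO[C@@H](C(=O)N[C@@H]1CCCCNC1=O)[C@H](O)[C@@H](O)[C@H](O)/C=C/C(C)(C)C` has not yet been measured in this assay. The change from compound 2 to compound 3 is 2-oxoazepan-3-yl in place of 6-hydroxy-2-oxoazepan-3-yl on an amide-type nitrogen. For the measured compounds named here, no measured step removes the hydroxy group from the seven-membered ring. Going by the values given here, the only step known, a 1.6-fold lower number from compound 1 to compound 2 (0.19 log units; within the scatter), concerns configuration alone and was within the scatter, so it gives no direct guide to the size of the present step. With nothing of this kind to lean on, the expectation is for no change beyond the scatter, with the range kept wide. Compound 3 is expected to give 28000 nM in this assay, between 8000 nM and 100000 nM, which corresponds to an expected step of a 1.2-fold higher number from compound 2 to compound 3 (0.08 log units; within the scatter).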

Compound 3, half-maximal inhibitory concentration: 500 nM
For compound 3 the middle estimate is 56-fold (1.75 log units) above the measured one; measured number outside the range, below it.
By their numbers in this assay, from the lowest: compound 3; then compounds 2 and 1 (each within the scatter of the next).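

In this assay, hydrogen in place of hydroxy on a saturated ring carbon gives a 73-fold lower number from compound 1 to compound 3 (1.86 log units; beyond the scatter), and 2-oxoazepan-3-yl in place of 6-hydroxy-2-oxoazepan-3-yl on an amide-type nitrogen gives a 47-fold lower number from compound 2 to compound 3 (1.67 log units; beyond the scatter). Both steps are large, so this ring substituent on the amide-type nitrogen is sensitive to the hydroxy group in both drawn forms of the hydroxylated ring, whereas a 1.6-fold lower number from compound 1 to compound 2 (0.19 log units; within the scatter) had shown no response beyond the scatter. The large change therefore follows the loss of the hydroxy group, not the difference within the hydroxylated pair, whose two members stand within the scatter of each other: the fact that compounds 1 and 2 differ only in the configuration as drawn.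

On these data alone, whether a methoxy group, a fluorine atom or an amine on the same ring carbon would give a number nearer to compound 3 or to the hydroxylated pair stays open, so it cannot yet be said whether the hydroxy group is a specific liability or whether any substituent there has the same effect. Also open, as far as these compounds go, is how far the number depends on the drawn configuration at the remaining ring stereocentre of compound 3.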